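The compounds below may be only part of what the source reports. "The series", "measured", "known", "first", "only" and "open" are said of these compounds alone.

Compound 1 `CCC(COc1cccc(C(F)(F)F)c1)OC(=O)NCc1ccccc1` — > 100000 nM
Compound 2 `CCC(COc1cccc(C(C)C)c1)OC(=O)NCc1ccccc1` — > 100000 nM

In an assay for inhibition of zeta-carotene desaturase, chloroplastic/chromoplastic (Capsicum annuum), using a Dixon plot, with a stated time of 8 h (on this read-out lower numbers stand for stronger inhibition and higher numbers for weaker inhibition), compound 1 gives only a limit, > 100000 nM. In this assay compound 2 likewise gives only a limit, > 100000 nM. Among the compounds with values here, the one measured step is a step that the two limits leave unreadable from compound 1 to compound 2, and both values sit at the limit (the limit of > 100000 nM in this assay, at which 2 of the 2 values shown sit). Where compound 2 stands is therefore known only as a limit, with no number behind it. Compound 3 `CCOC(=O)c1cccc(OCC(CC)OC(=O)NCc2ccccc2)c1` is not yet measured. It differs from compound 2 in one place: ethoxycarbonyl in place of isopropyl on an aromatic carbon. Within the data shown here, the single measured step bears on this change only in that neither group tried so far on this aromatic carbon has brought a value off the limit; its size and direction are not readable. The expected step is a number no higher from compound 2 to compound 3 (the limit leaves the size open), with no direction beyond the scatter claimed. Compound 3 is estimated at 100000 nM, between 30000 nM and 300000 nM, most probably reported again as a limit.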

Compound 3, half-maximal inhibitory concentration: > 100000 nM
Compound 3 was reported as a limit; the forecaster's own chance of this, stated with the estimate: 75%; the middle value sits exactly at the limit.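

Compound 3 gives only a limit in this assay, > 100000 nM, so no step to it from compound 1 or compound 2 can be read: the limit of > 100000 nM in this assay, at which 3 of the 3 values shown sit.

The compounds shown leave open whether any group on this aromatic carbon gives a readable value in this assay.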